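The source may report more compounds than this note shows. Statements on the series, on what has been measured and on what is new or still open speak of the compounds shown alone.

Three amides on a shared core have been measured so far in a functional assay on MCF7 cells (Homo sapiens) for antiproliferative activity, read by MTT assay, with a stated time of 72 h; a lower number here means a stronger inhibitor, a higher number a weaker inhibitor. Compound 1 (`CCN1CCN(c2cc(C)c3cc(NC(=O)c4ccc(C)cc4)ccc3n2)CC1`) gives 6740 nM as its value, compound 2 (`CCN1CCN(c2cc(C)c3cc(NC(=O)c4cccnc4)ccc3n2)CC1`) gives 26600 nM as its value and compound 3 (`CCN1CCN(c2cc(C)c3cc(NC(=O)c4ccc5ccccc5n4)ccc3n2)CC1`) gives 7060 nM as its value. Compound 3 therefore stands level with compound 1 within the scatter, with compound 2 holding the highest number. Compound 4 (`CCN1CCN(c2cc(C)c3cc(NC(=O)c4ccco4)ccc3n2)CC1`) carries furan-2-yl in place of quinolin-2-yl on a carbonyl carbon. All three measured steps change this same place. The step of a 1.0-fold higher number from compound 1 to compound 3 (0.02 log units; within the scatter) stays within the scatter, whereas the step of a 3.9-fold higher number from compound 1 to compound 2 (0.60 log units; beyond the scatter) and the step of a 3.8-fold lower number from compound 2 to compound 3 (0.58 log units; beyond the scatter) are both modest. Among the compounds with values here, no furan-2-yl amide has been measured, so the guide is loose, and pyridin-3-yl is the only group here that has moved the number beyond the scatter. A modest rise in this assay is expected, no larger than those two steps, and the expected step is a 2.1-fold higher number from compound 3 to compound 4 (0.33 log units; beyond the scatter) in size. For compound 4 the estimated value is 15000 nM with an expected range from 5500 nM to 35000 nM in this assay.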

Compound 4, half-maximal inhibitory concentration: 41200 nM
Compound 4: middle estimate off by 2.7-fold (0.44 log units), on the low side, and the stated range ends below it.
By their numbers in this assay, from the lowest: compounds 1 and 3 (each within the scatter of the next); then compounds 2 and 4 (each within the scatter of the next).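

Furan-2-yl gives a 5.8-fold higher number from compound 3 to compound 4 (0.77 log units; beyond the scatter) in place of quinolin-2-yl and a 6.1-fold higher number from compound 1 to compound 4 (0.79 log units; beyond the scatter) in place of 4-methylphenyl, so a group of only 5 heavy atoms on the carbonyl carbon gives a number well clear of those two in this assay. Against pyridin-3-yl, furan-2-yl gives a 1.5-fold higher number from compound 2 to compound 4 (0.19 log units; within the scatter) and the two stand level, which shows that the higher level seen with compound 2 is not unique to one group. The four amides now fall into two levels, with both single-ring groups carrying a hetero atom at the higher numbers, while quinolin-2-yl, which also carries one, sits at the lower level with 4-methylphenyl.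

These compounds leave open whether a non-aromatic group such as cyclohexyl would sit at either level. They also leave open how a methoxy group or an amine on the phenyl ring would act. Nothing shown here accounts for the two levels.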